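A few compounds are considered here, and "the series" means these few. Any claim that something is new, unique, unknown or untested is made for them only; others in the source may bear on it.

Compound 2 `O=C(C1=C(Nc2ccc(Br)cc2)C(=O)N(CCCn2ccnc2)C1c1ccc(Br)cc1)c1ccccc1` gives 13000 nM in a functional assay on U2OS cells (Homo sapiens) for antiproliferative activity, read by MTT assay, with a stated time of 72 h; a higher number here means a weaker inhibitor, a lower number a stronger inhibitor. Among the compounds with values here, the only other number so far is that of compound 1 `CCOC1=C(C(=O)c2ccccc2)C(c2ccc(Br)cc2)N(CCCn2ccnc2)C1=O`, which gives 21900 nM in this assay; the two sit within the scatter of each other, the step being a 1.7-fold lower number from compound 1 to compound 2 (0.23 log units; within the scatter). Compound 3 `O=C(C1=C(NCc2ccccc2)C(=O)N(CCCn2ccnc2)C1c1ccc(Br)cc1)c1ccccc1` differs from compound 2 by benzyl in place of 4-bromophenyl on an amine nitrogen. Within the data shown here, no measured step touches the group on this amine nitrogen; the one step known, a 1.7-fold lower number from compound 1 to compound 2 (0.23 log units; within the scatter), concerns the substituent on the double-bonded ring carbon and stayed within the scatter. In this assay the expected step is therefore no change at the digits printed from compound 2 to compound 3 (within the scatter), nothing beyond the scatter. Compound 3 is estimated at 13000 nM, with a range from 5000 nM to 35000 nM.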

Compound 3, half-maximal inhibitory concentration: 32500 nM
Beside the measured number, compound 3's estimate is 2.5-fold (0.40 log units) below it; the range from low to high includes it.
By their numbers in this assay, from the lowest: compounds 2, 1 and 3 (each within the scatter of the next, the first and the last beyond it).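

In this assay the group on the amine nitrogen now shows a first readable effect: benzyl in place of 4-bromophenyl gives a 2.5-fold higher number from compound 2 to compound 3 (0.40 log units; beyond the scatter) on the shared core, a modest step. Measured against the ethoxy of compound 1, the benzylamino group gives only a 1.5-fold higher number from compound 1 to compound 3 (0.17 log units; within the scatter) and so does not separate from it. Nothing available gives a reason for the step between compound 2 and compound 3.

The compounds shown leave open whether a plain phenyl or a 2-phenylethyl group on this amine nitrogen would read closer to compound 2 or to compound 3. Going by these compounds, whether an unsubstituted amine at the double-bonded ring carbon would hold the value of either also remains open.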